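This account rests on a few compounds, and the source may have more. Where it says the series, first, only, none or still open, it means among the compounds named here.

Of the compounds shown here, three have been measured in an in vitro assay on Sf9 cells for inhibition of leukotriene A-4 hydrolase (Homo sapiens), read by immunoassay, with stated times of 10 min and 30 min; on this read-out higher numbers stand for weaker inhibition and lower numbers for stronger inhibition. Compound 1 `c1cnc2nc(Oc3ccc4c(CN5CCCCC5)coc4c3)sc2c1` gives 4.6 nM; compound 2 `O=C(O)C1CCN(Cc2coc3cc(Oc4nc5ncccc5s4)ccc23)CC1` gives 8.3 nM; compound 3 `CC(=O)NC1CCN(Cc2coc3cc(Oc4nc5ccccc5s4)ccc23)CC1` gives 26 nM. Among the compounds with values here, the one step among them that changes a single place is a 1.8-fold higher number from compound 1 to compound 2 (0.26 log units; within the scatter). Compound 3 stands highest of the three, beyond the scatter from both compound 2 and compound 1.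

Compound 4 `CC(=O)NC1CCN(Cc2coc3cc(Oc4nc5ncccc5s4)ccc23)CC1` is compound 3 with one change: a group of 9 heavy atoms (6 carbon, 2 nitrogen, 1 sulfur; one five-membered aromatic ring with 2 hetero atoms, one six-membered aromatic ring with 1 hetero atom) in place of a group of 9 heavy atoms (7 carbon, 1 nitrogen, 1 sulfur; one five-membered aromatic ring with 2 hetero atoms, one six-membered aromatic ring of carbon only), on an oxygen on an aromatic ring. Within the data shown here, no measured step covers this exchange, and the only measured step, from compound 1 to compound 2, concerns a different place. What can be said is that both compounds carrying the entering group sit at the lower numbers: compound 1 gives 4.6 nM and compound 2 gives 8.3 nM, while compound 3 with the leaving group gives 26 nM. On that basis compound 4 is expected to fall toward the lower numbers, a step of a 2.6-fold lower number from compound 3 to compound 4 (0.41 log units; beyond the scatter). The estimate for compound 4 in this assay is therefore 10 nM, with a range from 4 nM to 30 nM.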

Compound 4, half-maximal inhibitory concentration: 3.7 nM
Beside the measured number, compound 4's estimate is 2.7-fold (0.43 log units) above it, and the stated range ends above it.
By their numbers in this assay, from the lowest: compounds 4, 1 and 2 (each within the scatter of the next, the first and the last beyond it); then compound 3.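

In this assay, the exchange on an oxygen on an aromatic ring, where 1,3-benzothiazol-2-yl leaves and the group with a nitrogen in its six-membered aromatic ring enters, now has a direct reading with acetamido held in place: a 7.0-fold lower number from compound 3 to compound 4 (0.85 log units; beyond the scatter), beyond the scatter. With that entering group held in place, the saturated ring carbon also reads more clearly: acetamido in place of carboxy gives a 2.2-fold lower number from compound 2 to compound 4 (0.35 log units; beyond the scatter), beyond the scatter, whereas acetamido in place of hydrogen gives a 1.2-fold lower number from compound 1 to compound 4 (0.09 log units; within the scatter), within the scatter. Nothing available explains why either change acts as it does.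

On these data alone, it remains open whether the exchange on the oxygen gives a step of similar size when the saturated ring carbon carries carboxy or hydrogen instead of acetamido. As far as these compounds go, how an amine or a hydroxyl group on that carbon would read is also open.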